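Swapping the amide aryl group in compound 2

A few compounds are considered here, and "the series" means these few. Any claim that something is new, unique, unknown or untested is made for them only; others in the source may bear on it.

Compound 2 `CCN1CCN(c2cc(C)c3cc(NC(=O)c4ccc5ccccc5n4)ccc3n2)CC1` gives the highest number of the three compounds in a functional assay on MCF7 cells (Homo sapiens) for antiproliferative activity, read by MTT assay, with a stated time of 72 h (on this read-out lower numbers stand for stronger inhibition and higher numbers for weaker inhibition), at 7060 nM; compound 1 `Cc1cc(NCCN2CCN(C)CC2)nc2ccc(NC(=O)c3ccc(Cl)c(Cl)c3)cc12` gives 1700 nM and compound 3 `Cc1cc(NCCN2CCCCC2)nc2ccc(NC(=O)c3ccc(Cl)c(Cl)c3)cc12` gives 1190 nM, both beyond the scatter from compound 2. Compound 4 `CCN1CCN(c2cc(C)c3cc(NC(=O)c4ccc(C)cc4)ccc3n2)CC1` differs from compound 2 by 4-methylphenyl in place of quinolin-2-yl on a carbonyl carbon. Within the data shown here, the only measured step, a 1.4-fold lower number from compound 1 to compound 3 (0.15 log units; within the scatter), concerns the chain amine and not the amide aryl group, so no step bears directly on this change; compounds 1 and 3 carry a different aryl amide but also a different chain, so their lower numbers cannot be traced to the aryl group alone. The expected step is therefore modest and uncertain, a 1.6-fold lower number from compound 2 to compound 4 (0.20 log units; within the scatter), and compound 4 is estimated at 4500 nM, between 1200 nM and 17000 nM.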

Compound 4, half-maximal inhibitory concentration: 6740 nM
Estimate against measurement, compound 4: 1.5-fold (0.18 log units) below, and the stated range covers the measured number.
By their numbers in this assay, from the lowest: compounds 3 and 1 (each within the scatter of the next); then compounds 4 and 2 (each within the scatter of the next).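

In this assay, 4-methylphenyl in place of quinolin-2-yl on the carbonyl carbon gives a 1.0-fold lower number from compound 2 to compound 4 (0.02 log units; within the scatter) and so leaves the number within the scatter. At this position, a single carbon-only ring therefore reads like the larger two-ring group with its ring nitrogen, and this swap alone does not reach the lower numbers of compounds 1 and 3. No measurement at hand offers an explanation for this result.

Whether those lower numbers follow the aryl amide or the amine chain stays open, as no pair shown separates the two. Also open, as far as these compounds go, is how an amine or a carboxylic acid on the phenyl ring would read.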